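Side-chain change from compound 2 to compound 3

The source may hold more compounds than are shown below. What is called first, only, known or untested is meant among the compounds shown, and "the series" means these compounds.

Measured so far in a functional assay on HCT-116 cells (Homo sapiens) for antiproliferative activity, read by sulforhodamine B assay, with a stated time of 72 h; on this read-out higher numbers stand for weaker inhibition and lower numbers for stronger inhibition
- compound 1 `CNC(=O)C[C@@H]1C[C@@H](c2ccc(Cl)c(Cl)c2)[C@H](NC(=O)c2cc(-c3c(Cl)cnn3C)c(Cl)o2)CN1` gives 450 nM
- compound 2 `Cn1ncc(Cl)c1-c1cc(C(=O)N[C@@H]2CN[C@H](CCO)C[C@H]2c2ccc(F)c(F)c2)oc1Cl` gives 360 nM

Compound 2 stands within the scatter of compound 1, so these two values carry no order. The next entry is compound 3 `CNC(=O)C[C@@H]1C[C@@H](c2ccc(F)c(F)c2)[C@H](NC(=O)c2cc(-c3c(Cl)cnn3C)c(Cl)o2)CN1`, not yet measured. It has methylcarbamoyl in place of the hydroxymethyl of compound 2, on a saturated chain carbon bound to a saturated ring carbon (methylcarbamoyl in place of hydroxymethyl on a saturated chain carbon bound to a saturated ring carbon). Cut one bond further out, this reads 2-hydroxyethyl to (methylcarbamoyl)methyl. Within the data shown here, no step between measured compounds isolates this change. Methylcarbamoyl also occurs in compound 1 (450 nM), a value within the scatter of compound 2, so no shift beyond the scatter is expected in this assay for this change. The expected step is small (a 1.1-fold higher number from compound 2 to compound 3 (0.05 log units; within the scatter)). The estimate for compound 3 is 400 nM (expected range 150 nM to 1000 nM).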

Compound 3, half-maximal inhibitory concentration: 1100 nM
Compound 3: the middle estimate sits 2.8-fold (0.44 log units) below what was measured; measured number above the stated range.
By their numbers in this assay, from the lowest: compounds 2 and 1 (each within the scatter of the next); then compound 3.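

In this assay methylcarbamoyl in place of hydroxymethyl on a saturated chain carbon bound to a saturated ring carbon gives a 3.1-fold higher number from compound 2 to compound 3 (0.49 log units; beyond the scatter) and thus a step beyond the scatter, so this position is not indifferent to the side chain when 3,4-difluorophenyl is present. With methylcarbamoyl held constant, 3,4-difluorophenyl in place of 3,4-dichlorophenyl on a saturated ring carbon gives a 2.4-fold higher number from compound 1 to compound 3 (0.39 log units; beyond the scatter) and shows that the aryl substituents also alter the read-out. No measurement offered here explains either step.

The compounds shown leave open whether the side-chain step belongs to the amide or to the larger group as a whole, which an aminomethyl or carboxymethyl group at this place could help separate. Also open, from the compounds shown here alone, is the size of the side-chain step with 3,4-dichlorophenyl present.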